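The compounds below may be only part of what the source reports. "The series", "measured", "known", "first", "only" and "open" are said of these compounds alone.

Measured so far in an assay on isolated protein for inhibition of DNA topoisomerase 1 (Homo sapiens), tested at 100 uM; a lower number here means less inhibition, a higher number more inhibition at the concentration tested (going by the name of the read-out):
Compound 1 `COc1ccc(/C=C/C(=O)c2ccc(OCC3CO3)cc2)cc1` gives 0%.
Compound 2 `COc1ccc(C(=O)/C=C/c2ccc(OCC3CO3)cc2)cc1` gives 0%.
Compound 3 `O=C(/C=C/c1ccc(OCC2CO2)cc1)c1ccc(OCC2CO2)cc1` gives 0%.

In this assay compound 3 stands level with compounds 1 and 2; all three show no inhibition at the digits read. The two measured steps that reach compound 3, no change at the digits printed from compound 1 to compound 3 (within the scatter) and no change at the digits printed from compound 2 to compound 3 (within the scatter), each put oxiran-2-yl in place of hydrogen on a saturated chain carbon bound to an oxygen on an aromatic ring, and neither moved the read-out.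

Compound 4 `COc1cc(OCC2CO2)ccc1/C=C/C(=O)c1ccc(OCC2CO2)cc1` differs from compound 3 by methoxy in place of hydrogen on an aromatic carbon. Going by the values given here, no measured step adds a methoxy in this way, so the expectation rests on the flat picture across compounds 1, 2 and 3. The estimate for compound 4 is 0%, expected to lie between 0% and 10%. The expected step, no change at the digits printed from compound 3 to compound 4 (within the scatter), is no change beyond the scatter.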

Compound 4, a percentage reported as inhibition, at one concentration (the size of the read-out at that concentration, not a potency): 0%
Estimate against measurement, compound 4: no gap at the digits printed, within the range that was stated.
By their numbers in this assay, from the lowest: compounds 1, 2, 3 and 4 (each within the scatter of the next).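

Putting methoxy in place of hydrogen on an aromatic carbon, ortho to a large group and meta to a (oxiran-2-yl)methoxy group, gives no change at the digits printed from compound 3 to compound 4 (within the scatter) in this assay as the first test of this change. On a compound already carrying two (oxiran-2-yl)methoxy groups, this substitution does not bring inhibition into view. No measured information is available to explain this flat result.

On these data alone, whether an amine or a carboxylic acid at this aromatic carbon would give any inhibition stays open. Also open, as far as these compounds go, is whether methoxy here would matter on a compound with measurable inhibition.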